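Swapping cyclohexyl for cyclopropyl on the shared core

This account rests on a few compounds, and the source may have more. Where it says the series, first, only, none or still open, it means among the compounds named here.

Compounds measured so far:
- compound 1, `CC#C[C@@H](Cc1nnn[nH]1)c1ccc(OCc2ccc3scc(C4CCCCC4)c3c2)cc1`, 107 nM
- compound 2, `CC#C[C@@H](Cc1nnn[nH]1)c1ccc(OCc2ccc3scc(-c4ccc(OCCC(C)(C)O)cc4C)c3c2)cc1`, 8 nM

In a functional assay on cells for agonist activity at Free fatty acid receptor 1 (Homo sapiens), read by FLIPR and calcium flux (on this read-out higher numbers stand for an effect only at larger amounts of compound and lower numbers for an effect already at smaller amounts), compound 1 gives 107 nM, the highest of the two numbers recorded. In this assay compound 2 gives 8 nM, a lower number by a margin beyond the usual scatter, so compound 2 acts at smaller amounts than compound 1. For the measured compounds named here, compound 2 carries a substituted phenyl group where compound 1 carries cyclohexyl; this is the only comparison available, and no single-change step between measured compounds exists.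

Compound 3, `CC#C[C@@H](Cc1nnn[nH]1)c1ccc(OCc2ccc3scc(C4CC4)c3c2)cc1`, has not yet been measured. It differs from compound 1 in one place: cyclopropyl in place of cyclohexyl on an aromatic carbon. The ring at this position shrinks from six carbons to three.

Going by the values given here, since the only measured neighbour, compound 2, reaches a lower number with a bulkier group at this position, a smaller group is expected to move the number upward rather than downward, though by an uncertain amount. The step from compound 1 to compound 3 is therefore estimated as a 3.3-fold higher number from compound 1 to compound 3 (0.51 log units; beyond the scatter) in this assay. For compound 3 the expected value in this assay is 350 nM, with a plausible range from 100 nM to 1500 nM.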

Compound 3, half-maximal effective concentration: 858 nM
Compound 3: middle estimate off by 2.5-fold (0.39 log units), on the low side; low and high end bracket the measured number.
By their numbers in this assay, from the lowest: compound 2; then compound 1; then compound 3.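

In this assay, for the compounds shown here, putting cyclopropyl in place of cyclohexyl on this aromatic carbon gives an 8.0-fold higher number from compound 1 to compound 3 (0.90 log units; beyond the scatter), the first direct reading of a single change at this position. It shows that the position is sensitive to the size of a plain carbon ring: neither group has hydrogen-bond donors, hydrogen-bond acceptors or a net charge, yet going from the six-membered ring to the three-membered ring means that much more compound is needed for the same effect. Nothing measured here explains why the smaller ring behaves this way.

Two ring sizes give only two points, so they cannot show whether the number changes steadily with ring size or whether a cyclopentyl ring would land between them. From the compounds shown here alone, it also remains open whether an open chain such as butyl would behave like the carbon rings, and whether adding an amine to the cyclohexyl ring would keep, raise or lower the number.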